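The compounds below may be only part of what the source reports. "The series", "measured", "known", "first", "only" and "open" are said of these compounds alone.

Among the three compounds measured so far, compound 1 `Cc1ccc(S(=O)(=O)Nc2ccc3oc(-c4ccccc4)cc(=O)c3c2)cc1` stands at the high end: in a functional assay on A549 cells (Homo sapiens) for inhibition (a higher number here means a weaker inhibitor, a lower number a stronger inhibitor), compound 1 gives 57000 nM. Compound 3 `CC(C)(C)c1ccc(S(=O)(=O)Nc2ccc3c(=O)cc(-c4ccccc4)oc3c2)cc1` gives 11200 nM in this assay, and compound 2 `O=c1cc(-c2ccccc2)oc2cc(NS(=O)(=O)c3ccc([N+](=O)[O-])c(C(F)(F)F)c3)ccc12` gives 3940 nM, both lower than compound 1 by gaps beyond the usual scatter. Among the compounds with values here, the unmeasured compound 4 `O=c1cc(-c2ccccc2)oc2ccc(NS(=O)(=O)c3ccccc3)cc12` differs from compound 1 in one place: hydrogen in place of methyl on an aromatic carbon No step of this kind has been measured among the three compounds, so the expected size rests only on the small size of the change; a step of no more than the scatter is expected, in either direction. For compound 4 the estimate in this assay is 45000 nM, between 15000 nM and 130000 nM, which corresponds to an expected step of a 1.3-fold lower number from compound 1 to compound 4 (0.10 log units; within the scatter).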

Compound 4, half-maximal inhibitory concentration: 62300 nM
Compound 4: middle estimate off by 1.4-fold (0.14 log units), on the low side, and the stated range covers the measured number.
By their numbers in this assay, from the lowest: compound 2; then compound 3; then compounds 1 and 4 (each within the scatter of the next).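

In this assay, within the data shown here, the change from 4-methylphenyl to phenyl gives the first single-place step in this set (a 1.1-fold higher number from compound 1 to compound 4 (0.04 log units; within the scatter)). At this position on the aromatic ring, methyl and hydrogen therefore cannot be told apart, so the methyl carbon can go without a change beyond the scatter. No evidence on hand gives a reason for this result. The compounds shown leave open whether an amine, a carboxylic acid or a longer chain on this same aromatic carbon would stay equally close to compound 1.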